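The compounds below may be only part of what the source reports. "The series", "measured", "known", "first", "only" and "open" are said of these compounds alone.

Three pyrazolyl chalcones have been measured in a functional assay on KM12 cells (Homo sapiens) for inhibition, read by sulforhodamine B assay, with a stated time of 48 h; on this read-out lower numbers stand for stronger inhibition of growth and higher numbers for weaker inhibition of growth. Compound 1 `COc1ccc(-c2cc(/C=C/C(=O)c3ccc(OC)c(OC)c3)[nH]n2)cc1` gives 1380 nM. Compound 2 `COc1cc(-c2cc(/C=C/C(=O)c3ccc(Cl)c(Cl)c3)[nH]n2)cc(OC)c1OC` gives 3370 nM. Compound 3 `COc1ccc(-c2cc(/C=C/C(=O)c3cc(OC)c(OC)c(OC)c3)[nH]n2)cc1OC` gives 780 nM, the lowest number of the three. Compound 1 lies within the usual scatter of compound 3, so the two cannot be told apart on these numbers; compound 2 lies beyond the scatter of compound 3, the only gap among the three that is clearly larger than repeat measurements would produce. No pair of these compounds differs in a single place, so no step can be followed between measured compounds.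

Compound 4 `COc1cc(C(=O)/C=C/c2cc(-c3cc(OC)c(OC)c(OC)c3)n[nH]2)cc(OC)c1OC` has not yet been measured in this assay. Against compound 3 the change is methoxy in place of hydrogen on an aromatic carbon. The group enters ortho to a methoxy group and meta to a methoxy group, on the ring that carries the pyrazole.

Within the data shown here, with no measured step to build on, the step from compound 3 to compound 4 is expected to be small, a 1.2-fold higher number from compound 3 to compound 4 (0.06 log units; within the scatter), with no direction favoured beyond the scatter. Compound 4 is therefore estimated at 900 nM, with a range from 350 nM to 2500 nM.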

Compound 4, concentration for 50% growth inhibition: 1490 nM
Estimate against measurement, compound 4: 1.7-fold (0.22 log units) below; the measured number falls inside the stated range.
By their numbers in this assay, from the lowest: compounds 3, 1 and 4 (each within the scatter of the next); then compound 2.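

In this assay, the series now offers its first step in a single place: methoxy in place of hydrogen on an aromatic carbon gives a 1.9-fold higher number from compound 3 to compound 4 (0.28 log units; within the scatter). The earlier compounds shown here, none of which differed in a single place, could not show that this position, ortho to a methoxy group and meta to a methoxy group on the ring that carries the pyrazole, accepts a methoxy group with a difference that cannot be told apart from repeat measurements. No measurement available here offers an explanation for this result.

This single step does not show whether a hydroxy group, an amine, a carboxylic acid or a longer alkoxy chain at the same position would also stay within the scatter or would move the number beyond it. It also leaves open whether methoxy at this position would give a similar step in compounds with chlorine in place of the methoxy groups on the other aromatic ring.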